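From Acetamido to Propanoylamino: Expected Cytotoxicity

This account rests on a few compounds, and the source may have more. Where it says the series, first, only, none or still open, it means among the compounds named here.

Of the compounds shown here, three have been measured in an ADME assay on MT4 cells (Homo sapiens) for cytotoxicity, read by MTT assay, with a stated time of 96 h; on this read-out lower numbers stand for higher toxicity in this test and higher numbers for lower toxicity in this test. Compound 1, `COc1ccc(-c2nc3cc(Cl)c(Cl)cc3[nH]2)cc1`, gives 1000 nM. Compound 3, `O=[N+]([O-])c1ccc(-c2nc3cc(C(F)(F)F)ccc3[nH]2)c([N+](=O)[O-])c1`, gives 9000 nM in this assay. Compound 2, `CC(=O)Nc1ccc(-c2nc3cc(C(F)(F)F)ccc3n2C)cc1`, gives 15000 nM in this assay, the highest of the three numbers; the value of compound 3 lies within the scatter of it, so the two cannot be told apart, while the value of compound 1 sits well beyond the scatter on the more toxic side.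

Compound 4, `CCC(=O)Nc1ccc(-c2nc3cc(C(F)(F)F)ccc3n2C)cc1`, has not yet been measured. It differs from compound 2 in one place: methyl in place of hydrogen on a saturated chain carbon bound to a carbonyl carbon. Among the compounds with values here, no measured pair here shows what this change does, so no step beyond the scatter is expected in either direction, and the number for compound 4 is expected to sit near that of compound 2.

Compound 4 is expected to give about 15000 nM in this assay, within a range from 6000 nM to 40000 nM. The step that this estimate means, no change at the digits printed from compound 2 to compound 4 (within the scatter), is expected to stay inside the usual scatter.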

Compound 4, half-maximal cytotoxic concentration: 8000 nM
The estimate for compound 4 lay 1.9-fold (0.27 log units) above the measured number, and the stated range covers the measured number.
By their numbers in this assay, from the lowest: compound 1; then compounds 4, 3 and 2 (each within the scatter of the next).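

Adding a methyl to the acetamido group to give propanoylamino produces a 1.9-fold lower number from compound 2 to compound 4 (0.27 log units; within the scatter) in this assay, so the two compounds cannot be told apart on this read-out. Within the data shown here, this is the first pair here that differs in only one place, and it shows that a methyl in place of hydrogen on this saturated chain carbon bound to a carbonyl carbon brings no step beyond the scatter. Nothing else at hand bears on this result.

Still open, from the compounds shown here alone, is whether a longer chain such as butanoyl, or an amine or a carboxylic acid at this same carbon, would also stay within the scatter. This is also a single pair, so it cannot show whether the same change would act alike on a different core.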